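The compounds below may be only part of what the source reports. "The series", "measured", "known", "first", "only" and "open" are said of these compounds alone.

Measured so far in a functional assay on the whole organism with Rattus norvegicus as the target; on this read-out higher numbers stand for an effect only at larger amounts of compound and lower numbers for an effect already at smaller amounts 
- compound 1 `CC(C)(C)Oc1ccc2nc(N)sc2c1` gives > 10 mg/kg as a limit
- compound 2 `Nc1nc2ccc(C3CCCCC3)cc2s1` gives > 10 mg/kg as a limit
- compound 3 `CC(C)c1ccc2nc(N)sc2c1` gives > 10 mg/kg as a limit

Compound 1 offers no number to start from, only > 10 mg/kg as a limit of the assay. It has company there, for the whole set shows the limit of > 10 mg/kg in this assay, at which 3 of the 3 values shown sit, and so no ranking of the three can be read.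

Compound 4 `CC(C)(C)Cc1ccc2nc(N)sc2c1` has not yet been measured. Its difference from compound 1 is neopentyl in place of tert-butoxy on an aromatic carbon and in words this is neopentyl in place of tert-butoxy on an aromatic carbon, with the rest of the core unchanged.

Among the measured compounds shown here, the one measured step that bears on this also replaces tert-butoxy, with isopropyl in its place. That step is a step that the two limits leave unreadable from compound 1 to compound 3 and it has a limit at both ends, so it hands on no size to carry over. Nothing measured points either way. The step expected in this assay is a step that the limit leaves unreadable from compound 1 to compound 4 and no direction for it can be argued from these data. Compound 4 is most likely to be reported only as a limit as well. For compound 4 the estimate is 15 mg/kg with an expected range from 6 mg/kg to 40 mg/kg on this read-out.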

Compound 4, dose for half-maximal effect: > 10 mg/kg
Compound 4: only a limit was reported; the forecaster's own chance of this, stated with the estimate: 75%; the middle value lies beyond the limit too.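

No step from compound 1 or compound 3 to compound 4 can be read in this assay, because each compound gives a limit rather than a number: the limit of > 10 mg/kg in this assay, at which 4 of the 4 values shown sit.

The compounds shown leave open how compound 1, compound 2, compound 3 and compound 4 rank, and at what dose each would reach half-maximal effect.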